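Lengthening the amide chain on the shared core

This account rests on a few compounds, and the source may have more. Where it says the series, first, only, none or still open, it means among the compounds named here.

Measured compounds:
- compound 1 `CNC(=O)c1cc(Oc2ccc(NC(=O)c3cc4cccnc4n(-c4ccc(F)cc4)c3=O)cc2)ccn1`: 160 nM
- compound 2 `CNC(=O)c1cc(Oc2ccc(NC(=O)c3cc4cccnc4n(-c4ccc(Cl)cc4)c3=O)cc2)ccn1`: 390 nM
- compound 3 `CNC(=O)c1cc(Oc2ccc(NC(=O)c3cc4cccnc4n(-c4ccc(Br)cc4)c3=O)cc2)ccn1`: 1180 nM

In a functional assay on HT-29 cells (Homo sapiens) for antiproliferative activity, read by MTT assay, with a stated time of 72 h (on this read-out higher numbers stand for weaker inhibition and lower numbers for stronger inhibition), compound 1 gives the lowest number of the three. The measured steps, a 2.4-fold higher number from compound 1 to compound 2 (0.39 log units; beyond the scatter) and a 7.4-fold higher number from compound 1 to compound 3 (0.87 log units; beyond the scatter), all concern the halogen on the aromatic carbon. Compound 4 `CCNC(=O)c1cc(Oc2ccc(NC(=O)c3cc4cccnc4n(-c4ccc(F)cc4)c3=O)cc2)ccn1` differs from compound 1 elsewhere: methyl in place of hydrogen on a saturated chain carbon bound to an amide-type nitrogen, turning methylcarbamoyl into ethylcarbamoyl. Among the compounds with values here, no measured step touches this part of the core, so nothing here tells how such a change acts. In this assay compound 4 is therefore expected to give a number close to that of compound 1, with a step of a 1.3-fold higher number from compound 1 to compound 4 (0.10 log units; within the scatter) that need not exceed the scatter. The estimate for compound 4 is 200 nM, within 70 nM to 600 nM.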

Compound 4, half-maximal inhibitory concentration: 190 nM
Compound 4: middle estimate off by 1.1-fold (0.02 log units), on the high side; the range from low to high includes it.
By their numbers in this assay, from the lowest: compounds 1 and 4 (each within the scatter of the next); then compound 2; then compound 3.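

In this assay the change from methylcarbamoyl to ethylcarbamoyl is a 1.2-fold higher number from compound 1 to compound 4 (0.07 log units; within the scatter) and so cannot be told apart from repeat measurements. Within the data shown here, this is the first sign that this part of the molecule, unlike the halogen position, can take one added methyl without a clear change in the number. Nothing measured here explains this result.

As far as these compounds go, a longer chain such as propyl, a cyclopropyl ring or a terminal amine on this amide remains open. So does whether ethylcarbamoyl behaves the same alongside chloro or bromo.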